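This account rests on a few compounds, and the source may have more. Where it says the series, first, only, none or still open, it means among the compounds named here.

In an ADME assay on L6 cells (Rattus norvegicus) for cytotoxicity, read by fluorescence and resazurin assay, with a stated time of 72 h (a lower number here means that less compound is tolerated, a higher number that more compound is tolerated), compound 1 `N#Cc1ccc(-c2c[nH]cc2C(c2ccc(Cl)cc2Cl)n2ccnc2)cc1` gives 15000 nM, and compound 2 `CSc1ccc(-c2c[nH]cc2C(c2ccc(Cl)cc2Cl)n2ccnc2)cc1` gives 7220 nM, the lower of the two numbers. Compound 3 `Clc1ccc(C(c2c[nH]cc2-c2ccc(-c3ccccc3)cc2)n2ccnc2)c(Cl)c1` differs from compound 2 by phenyl in place of methylsulfanyl on an aromatic carbon, with phenyl in place of methylsulfanyl on an aromatic carbon, para to a large group. For the measured compounds named here, the only measured guide is a 2.1-fold lower number from compound 1 to compound 2 (0.32 log units; beyond the scatter), a modest change that also swapped the group on an aromatic carbon. With so little evidence, only a small shift towards a lower number is expected, possibly lost in the scatter. The expected change is a 1.4-fold lower number from compound 2 to compound 3 (0.16 log units; within the scatter). For compound 3 the estimate is 5000 nM, with an expected range from 2000 nM to 13000 nM.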

Compound 3, half-maximal cytotoxic concentration: > 202000 nM
Compound 3 ended at the assay's limit; the forecaster's own chance of this, stated with the estimate: 5%; middle value at least 40-fold (1.60 log units) away from the limit.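

In this assay, the group on this aromatic carbon, para to a large group, proves able to move the number much further than the first two compounds showed. Phenyl in place of methylsulfanyl gives an at least 27-fold higher number from compound 2 to compound 3 (1.44 log units; beyond the scatter), and phenyl in place of cyano gives an at least 13-fold higher number from compound 1 to compound 3 (1.12 log units; beyond the scatter), both far larger than a 2.1-fold lower number from compound 1 to compound 2 (0.32 log units; beyond the scatter). The value of compound 3 is a limit, so both steps are minimum sizes: the limit of > 202000 nM in this assay, at which 1 of the 3 values shown sits.

Going by these compounds, it remains open whether this jump needs an aromatic ring at this carbon or whether a longer chain would give the same. On these data alone, how an amine or a carboxylic acid would read here is also open.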